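This account rests on a few compounds, and the source may have more. Where it says the series, first, only, none or still open, it means among the compounds named here.

Measured compounds:
compound 1 `CC(C)C(=O)N1CC2CC(C1)N2` gives 71%
compound 2 `O=C([C@H]1C[C@H]1F)N1CC2CC(C1)N2` gives 110%
compound 3 `C[C@@H]1C[C@@H]1C(=O)N1CC2CC(C1)N2` gives 97%

All three values come from an assay on SH-EP1 cells for agonist activity at Neuronal acetylcholine receptor; alpha4/beta2 (Homo sapiens), read by FLIPR and calcium flux; on this read-out lower numbers stand for smaller maximal responses and higher numbers for larger maximal responses. Compound 1 has the lowest maximal response of the three measured compounds: the nearest is compound 3, and the step of a number 26 percentage points higher from compound 1 to compound 3 (beyond the scatter) lies beyond the scatter, while the step of a number 39 percentage points higher from compound 1 to compound 2 (beyond the scatter) is the larger of the two. Between the two cyclopropyl amides the step of a number 13 percentage points lower from compound 2 to compound 3 (beyond the scatter) is also beyond the scatter.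

Compound 4 `C[C@H]1C[C@@H]1C(=O)N1CC2CC(C1)N2` is not yet measured. Relative to compound 1 the change is 2-methylcyclopropyl in place of isopropyl on a carbonyl carbon. Compound 3 carries the same 2-methylcyclopropyl group with a different stereochemical arrangement, so the step of a number 26 percentage points higher from compound 1 to compound 3 (beyond the scatter) is the closest guide; the step of a number 39 percentage points higher from compound 1 to compound 2 (beyond the scatter) shows that the other cyclopropyl group raised the response further still. Both steps point upward and beyond the scatter. Compound 4 is therefore expected to show a step of about a number 24 percentage points higher from compound 1 to compound 4 (beyond the scatter) in this assay , upward. Going by the values given here, for compound 4 the estimated maximal response is 95%, with a range from 80% to 112%, the uncertainty reflecting that no step between the two stereochemical arrangements of the 2-methylcyclopropyl group has been measured.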

Compound 4, largest response reached (Emax), in percent of the reference or control that the assay uses: 85%
Estimate against measurement, compound 4: 10 percentage points above, and the stated range covers the measured number.
By their numbers in this assay, from the lowest: compound 1; then compound 4; then compound 3; then compound 2.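

In this assay, replacing isopropyl with 2-methylcyclopropyl on the carbonyl carbon does not give one fixed gain: this arrangement of the group gives a number 14 percentage points higher from compound 1 to compound 4 (beyond the scatter), so the response still rises, but the size of the rise depends on how the group is drawn. The two 2-methylcyclopropyl amides can now be compared directly, and the result is a number 12 percentage points lower from compound 3 to compound 4 (beyond the scatter), which shows that a stereochemical difference alone at this position can move the maximal response beyond the scatter, although the comparison carries a caveat in how the pair is drawn: the fact that one of compounds 3 and 4 is drawn with a defined configuration and the other without, at the place where they differ The 2-fluorocyclopropyl amide keeps the largest response of the four, and exchanging its group for this 2-methylcyclopropyl group gives a number 25 percentage points lower from compound 2 to compound 4 (beyond the scatter), a wider gap than the one seen with the other methyl arrangement.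

The compounds shown leave open whether the drawn configuration would change the response in the same way for the 2-fluorocyclopropyl group, since only one arrangement of it appears here. They also leave open how an unsubstituted cyclopropyl group, a tert-butyl group or an amine on the same carbonyl carbon would read.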